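Capping the amine of compound 3 as a urea

The source may report more compounds than this note shows. Statements on the series, on what has been measured and on what is new or still open speak of the compounds shown alone.

Three compounds share one core and differ only in the group on the sulfur-bound chain. Compound 1 `CC(C)c1n[nH]c2c(NCc3ccc(-c4ccccn4)cc3)nc(SCC(C)(C)O)nc12` carries a 1-hydroxy-1-methylethyl there; in a functional assay on HT cells (Homo sapiens) for antiproliferative activity, read by fluorescence, with a stated time of 72 h (a lower number here means a stronger inhibitor of growth, a higher number a weaker inhibitor of growth), compound 1 gives 507 nM. Compound 2 `CC(C)c1n[nH]c2c(NCc3ccc(-c4ccccn4)cc3)nc(SCC(O)CN)nc12` carries a 2-amino-1-hydroxyethyl, and compound 2 gives 55 nM. Compound 3 `CC(C)c1n[nH]c2c(NCc3ccc(-c4ccccn4)cc3)nc(SCCN)nc12` carries an aminomethyl, and compound 3 gives 22 nM, the lowest of the three numbers, with a 2.5-fold lower number from compound 2 to compound 3 (0.40 log units; beyond the scatter) and a 23-fold lower number from compound 1 to compound 3 (1.36 log units; beyond the scatter).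

Compound 4 `CC(C)c1n[nH]c2c(NCc3ccc(-c4ccccn4)cc3)nc(SCCNC(N)=O)nc12` is compound 3 with carbamoyl in place of hydrogen on an amine nitrogen, so the chain reads 2-ureidoethyl instead of 2-aminoethyl. Among the compounds with values here, no measured step changes the amine nitrogen itself, so the bearing is indirect: the two steps ending in compound 3, a 23-fold lower number from compound 1 to compound 3 (1.36 log units; beyond the scatter) and a 2.5-fold lower number from compound 2 to compound 3 (0.40 log units; beyond the scatter), show that the free amine went with the lowest numbers, and compound 1, lacking an amine, gave the highest. Replacing the amine hydrogen with carbamoyl is therefore expected to raise the number modestly, about a 5.0-fold higher number from compound 3 to compound 4 (0.70 log units; beyond the scatter). Compound 4 is estimated at 110 nM, within 35 nM to 400 nM.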

Compound 4, concentration for 50% growth inhibition: 240 nM
Compound 4: middle estimate off by 2.2-fold (0.34 log units), on the low side; the measured number falls inside the stated range.
By their numbers in this assay, from the lowest: compound 3; then compound 2; then compound 4; then compound 1.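

In this assay, within the data shown here, the step is an 11-fold higher number from compound 3 to compound 4 (1.04 log units; beyond the scatter), the first direct reading of a change made on the amine nitrogen itself, and it shows that keeping this nitrogen while adding carbamoyl to it does not preserve the low number. The 2-ureidoethyl chain also sits behind the chain of compound 2, with a 4.4-fold higher number from compound 2 to compound 4 (0.64 log units; beyond the scatter), yet ahead of the chain of compound 1, which has no nitrogen, with a 2.1-fold lower number from compound 1 to compound 4 (0.32 log units; beyond the scatter), so among these four compounds the two chains with a free amine give the lowest numbers. No measurement shown explains why the capped amine behaves this way.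

On these data alone, it remains open whether any cap on this nitrogen raises the number this far, or only carbamoyl, as an acetyl or a single methyl there would tell. Also open, as far as these compounds go, is how the number responds to a longer chain ending in an amine, or to a carboxylic acid in place of the amine.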